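Saturating the Ether Chain of Compound 1

The source may report more compounds than this note shows. Statements on the series, on what has been measured and on what is new or still open speak of the compounds shown alone.

Compound 1 `CC(C)=CCOc1cccc(O)c1C(=O)/C=C/c1ccc(O)cc1` was tested in a functional assay on HCT-15 cells (Homo sapiens) for antiproliferative activity, read by sulforhodamine B assay; on this read-out higher numbers stand for weaker inhibition of growth and lower numbers for stronger inhibition of growth. In that assay compound 1 gives > 30000 nM, which is a limit of the assay and not a number. Compound 2 `COc1cccc(OCCC(C)(C)C)c1C(=O)/C=C/c1ccc(O)cc1` gives > 30000 nM in this assay, again a limit. Compound 3 `CC(C)(C)CCOc1cccc(O)c1C(=O)CCc1ccc(O)cc1` gives > 30000 nM in this assay, also a limit. Compound 1 therefore stands where every measured compound stands: the limit of > 30000 nM in this assay, at which 3 of the 3 values shown sit. Among the measured compounds shown here, no step between two measured compounds is available, so nothing measured tells how far a single structural change moves a value here.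

Compound 4 `CC(C)CCCOc1cccc(O)c1C(=O)/C=C/c1ccc(O)cc1` has not yet been measured. It differs from compound 1 in one place: isopentyl in place of 2-methylprop-1-en-1-yl on a saturated chain carbon bound to an oxygen on an aromatic ring. Because compound 1 shares (the limit of > 30000 nM in this assay, at which 3 of the 3 values shown sit), the step to compound 4 is expected to be none beyond the scatter, with compound 4 remaining at the limit: a step that the limit leaves unreadable from compound 1 to compound 4. Compound 4 is therefore estimated at 40000 nM, with a range from 20000 nM to 100000 nM.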

Compound 4, concentration for 50% growth inhibition: 11600 nM
For compound 4 the middle estimate is 3.4-fold (0.54 log units) above the measured one; measured number below the stated range.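

Setting 4-methylpentyl in place of 3-methylbut-2-en-1-yl on the ether oxygen gives an at least 2.5-fold lower number from compound 1 to compound 4 (0.41 log units; beyond the scatter) in this assay, and a lower number here means stronger inhibition of growth. This is the first readable step in the series, and it shows that a change in this ether chain alone can bring a compound off the limit, with compound 4 the only compound shown that gives a number: the limit of > 30000 nM in this assay, at which 3 of the 4 values shown sit.

Going by these compounds, the value of compound 1 is a limit and not a number, so the full size of this step stays unknown.

The compounds shown leave open whether the saturated chain or the extra chain carbon matters, which a 3-methylbutyl ether would separate. They also leave open how a longer chain such as octyl, or an amine at the chain end, would read in this assay.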